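Compound 2 to Compound 4: Phenyl Gives Way to Methyl

The source may hold more compounds than are shown below. What is called first, only, known or untested is meant among the compounds shown, and "the series" means these compounds.

Three compounds share a core, measured in an assay for inhibition of epoxide hydrolase 1 (Homo sapiens), read by fluorescence, using microsomes; on this read-out higher numbers stand for weaker inhibition and lower numbers for stronger inhibition. Compound 1 `O=C(NC(=S)Nc1ccc(Oc2ccccc2)cc1)c1ccccc1` gives 2100 nM; compound 2 `Cc1ccccc1NC(=S)NC(=O)c1ccccc1` gives 3540 nM; compound 3 `O=C(NC(=S)Nc1ccccc1)c1ccccc1` gives 1290 nM. Compound 2 holds the highest of the three numbers, with compound 1 within the scatter of it and compound 3 beyond it, as a 2.7-fold lower number from compound 2 to compound 3 (0.44 log units; beyond the scatter) shows. Compound 4 `CC(=O)NC(=S)Nc1ccccc1C` differs from compound 2 by methyl in place of phenyl on a carbonyl carbon. Neither measured step touches that position: a 1.6-fold lower number from compound 1 to compound 3 (0.21 log units; within the scatter) and a 2.7-fold lower number from compound 2 to compound 3 (0.44 log units; beyond the scatter) both alter the ring on the nitrogen side. With no guide for removing the phenyl, a weakening is expected, a 2.3-fold higher number from compound 2 to compound 4 (0.35 log units; beyond the scatter), so compound 4 is estimated at 8000 nM, between 2500 nM and 25000 nM.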

Compound 4, half-maximal inhibitory concentration: 1500 nM
For compound 4 the middle estimate is 5.3-fold (0.73 log units) above the measured one; measured number below the stated range.
By their numbers in this assay, from the lowest: compounds 3, 4, 1 and 2 (each within the scatter of the next, the first and the last beyond it).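

Methyl in place of phenyl on the carbonyl carbon gives a 2.4-fold lower number from compound 2 to compound 4 (0.37 log units; beyond the scatter) in this assay and so stronger inhibition, not weaker. Among these compounds, with compound 2 as the starting point, this position does not need the phenyl ring for inhibition, which the earlier steps, all elsewhere on the molecule, could not show. Nothing shown here accounts for this gain. As far as these compounds go, whether the same change would help compound 3 remains open. So does whether a longer chain such as propyl, or an amine, on the carbonyl carbon would shift the number further.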